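Taking Off the Cyclohexyl: What Happens to Cell Tolerance

A few compounds are considered here, and "the series" means these few. Any claim that something is new, unique, unknown or untested is made for them only; others in the source may bear on it.

Four related compounds share one core. Compound 1 `C/C(=N\NC(N)=S)c1ccc2[nH]c(-c3ccc(C(F)(F)F)cc3)nc2c1` carries a hydrogen on the ring nitrogen, compound 2 `C/C(=N\NC(N)=S)c1ccc2c(c1)nc(-c1ccc(C(F)(F)F)cc1)n2C1CCCCC1` carries a cyclohexyl there, compound 3 `C/C(=N\NC(N)=S)c1ccc2c(c1)nc(-c1ccoc1)n2C1CCCCC1` keeps that cyclohexyl but bears a furan-3-yl group, and compound 4 `C/C(=N\NC(N)=S)c1ccc2[nH]c(-c3ccoc3)nc2c1` has not yet been measured.

In an ADME assay on BHK-21 cells (Mesocricetus auratus) for cytotoxicity, read by MTT assay (a higher number here means that more compound is tolerated, a lower number that less compound is tolerated), compound 1 gives 5000 nM. For compound 2 the assay reports only a limit, > 100000 nM. For compound 3 the assay likewise reports only a limit, > 100000 nM.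

The change hydrogen in place of cyclohexyl on an aromatic nitrogen brings an at least 20-fold lower number from compound 2 to compound 1 (1.30 log units; beyond the scatter). The change furan-3-yl in place of 4-(trifluoromethyl)phenyl on an aromatic carbon gives a step that the two limits leave unreadable from compound 2 to compound 3 because of the limit of > 100000 nM in this assay, at which 2 of the 3 values shown sit.

Compound 4 differs from compound 3 by hydrogen in place of cyclohexyl on an aromatic nitrogen. The place differs from the earlier one only in that the ring atom next to it bears a furan-3-yl group rather than a 4-(trifluoromethyl)phenyl group, so this is the same kind of change, not the same change.

Compound 4 is expected to give 10000 nM. The expected step is an at least 10-fold lower number from compound 3 to compound 4 (1.00 log units; beyond the scatter), which rests on an at least 20-fold lower number from compound 2 to compound 1 (1.30 log units; beyond the scatter) and on the limit that compound 3 sits at.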

Compound 4, half-maximal cytotoxic concentration: > 100000 nM
Compound 4: no number, only a limit (the forecaster's own chance of this, stated with the estimate: 25%); middle value at least 10-fold (1.00 log units) away from the limit.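

The step from compound 3 to compound 4 cannot be read, because both compounds give only a limit and not a number: the limit of > 100000 nM in this assay, at which 3 of the 4 values shown sit.

The compounds shown leave open whether hydrogen in place of cyclohexyl changes how much compound is tolerated in this assay when the furan-3-yl group is present, as it does with the 4-(trifluoromethyl)phenyl group.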